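Three compounds at the upper limit, and a fourth to come

This account rests on a few compounds, and the source may have more. Where it says the series, first, only, none or still open, it means among the compounds named here.

Measured so far:
compound 1 `CCCCCC(=O)N[C@@H]1CCN(c2cc(C)nn3c(-c4ccc(OC)c(OC)c4)c(C)nc23)C1`: > 95%
compound 2 `COc1ccc(-c2c(C)nc3c(N4CC[C@@H](NC(=O)Oc5cccc(C)c5)C4)cc(C)nn23)cc1OC`: > 95%
compound 3 `COc1ccc(-c2c(C)nc3c(N4CC[C@@H](NS(=O)(=O)c5ccc(C)cc5)C4)cc(C)nn23)cc1OC`: > 95%

In an ADME assay on microsomes from liver (Homo sapiens) for metabolic stability, read by LC-MS, with NADPH named in the record, with a stated time of 60 min, tested at 1 uM, in the absence of a further agent (a higher number here means that more of the compound is left, a lower number that less of the compound is left), compound 1 gives > 95%, a limit of the assay and not a number. Compound 2 likewise gives > 95%, again a limit. Compound 3 stands at > 95%, which is also a limit, so its place among the three cannot be ranked. The steps a step that the two limits leave unreadable from compound 1 to compound 2, a step that the two limits leave unreadable from compound 1 to compound 3 and a step that the two limits leave unreadable from compound 2 to compound 3 are all of unreadable size because of the limit of > 95% in this assay, at which 3 of the 3 values shown sit.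

Compound 4 `COc1ccc(-c2c(C)nc3c(N4CC[C@@H](n5cc(-c6ccccc6)nn5)C4)cc(C)nn23)cc1OC` differs from compound 3 as follows: 4-phenyl-1H-1,2,3-triazol-1-yl in place of ((4-methylphenyl)sulfonyl)amino on a saturated ring carbon. Going by the values given here, none of the measured steps can be read for size or direction, so they give no guidance on whether this change moves the read-out beyond the scatter. The three measured compounds all sit at the limit, and that is the only anchor. Compound 4 is expected to give about 85%, within 55% to 100%. The estimated step this implies is a number at least 10 percentage points lower from compound 3 to compound 4 (that floor lies within the scatter), an expectation rather than a measurement.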

Compound 4, percent of the compound remaining: "unstable" (no number reported)
Nothing numeric was reported for compound 4, and the estimate cannot be compared.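

In this assay compound 4 is recorded as "unstable" (no number reported). Compound 3 has only a limit. Going by these compounds alone, no step from compound 3 to compound 4 can be read. On these data alone, how much of compound 4 remains, and how far it lies from compounds 1, 2 and 3, stays open.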